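A few compounds are considered here, and "the series" means these few. Any claim that something is new, unique, unknown or untested is made for them only; others in the source may bear on it.

Compound 2 `Cc1nn2c(-c3nc4ccccc4[nH]3)c(-c3ccccc3)nc2s1` marks the starting point in a functional assay on DU-145 cells (Homo sapiens) for antiproliferative activity, read by MTT assay; a higher number here means a weaker inhibitor, a lower number a stronger inhibitor. Compound 2 gives > 30000 nM, which is a limit of the assay and not a number. Compound 1 `Cc1nn2c(-c3nc4cc(Cl)ccc4[nH]3)c(-c3ccccc3)nc2s1`, which carries chloro on the same core, gives 25100 nM in this assay.

Compound 3 `Cc1nn2c(-c3nc4cc(F)ccc4[nH]3)c(-c3ccccc3)nc2s1` keeps the core of compound 2 and changes it in one place, fluoro in place of hydrogen on an aromatic carbon. Within the data shown here, the only measured step that bears on this change is an at least 1.1-fold higher number from compound 1 to compound 2 (0.07 log units; that floor lies within the scatter), in which hydrogen takes the place of chloro on an aromatic carbon. That step involves chloro rather than fluoro, and it gives only a floor that stays within the scatter. No step beyond the scatter is therefore expected in this assay, and compound 3 may well reach the limit of the assay too. The expected change is an at least 1.0-fold lower number from compound 2 to compound 3 (0.02 log units; that floor lies within the scatter). Compound 3 is estimated at 28000 nM, with an expected range from 14000 nM to 55000 nM.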

Compound 3, half-maximal inhibitory concentration: 16900 nM
The estimate for compound 3 lay 1.7-fold (0.22 log units) above the measured number; low and high end bracket the measured number.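

In this assay, fluoro on this aromatic carbon gives a second measured number on the shared core, so compound 1 and compound 3 both read as numbers, while compound 2, with hydrogen at this place, does not. The change from hydrogen to fluoro reads as an at least 1.7-fold lower number from compound 2 to compound 3 (0.24 log units; that floor lies within the scatter), and the exchange of one halogen for the other reads as a 1.5-fold lower number from compound 1 to compound 3 (0.17 log units; within the scatter), so chloro and fluoro cannot be told apart at this position in this assay. The true size of the step from hydrogen to fluoro stays unknown, and no effect beyond the scatter can be claimed for it, because compound 2 holds only a limit of the assay and not a number: the limit of > 30000 nM in this assay, at which 1 of the 3 values shown sits.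

The compounds shown leave open whether a group other than a halogen on this carbon, such as methoxy, an amine or a nitrile, would move the number beyond the scatter. They also leave open whether fluoro or chloro on another carbon of the same ring would read like compound 3 and compound 1, or whether the same exchange would hold on a different core.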